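The compounds below may be only part of what the source reports. "The series", "measured", "known", "first", "only" and "open" are said of these compounds alone.

Of the compounds shown here, two of a shared core have been tested so far in a functional assay on the whole organism (blood) with Rattus norvegicus as the target, with stated times of 24 h and 1 h, at a dose of 1 mg/kg by the intraperitoneal route; a higher number here means a stronger effect of the compound at the dose given, a lower number a weaker effect. Compound 1, `Cn1cccc(C(=O)NCCC2CCN(S(=O)(=O)NC(=O)NC[C@@H]3C[C@@H]4C=C[C@@H]3C4)CC2)c1=O`, gives 19% in this assay. Among the compounds with values here, compound 2, `O=C(NC[C@@H]1C[C@@H]2C=C[C@@H]1C2)NS(=O)(=O)N1CCC(CCNC(=O)c2cccc3cccnc23)CC1`, gives 32% and stands highest of the two numbers; its only measured step is a number 13 percentage points higher from compound 1 to compound 2 (beyond the scatter), a difference beyond the scatter.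

Compound 3, `Cn1cc(C(=O)NCCC2CCN(S(=O)(=O)NC(=O)NC[C@@H]3C[C@@H]4C=C[C@@H]3C4)CC2)c(=O)n(C)c1=O`, has not yet been measured. It differs from compound 2 in one place: a group of 10 heavy atoms (6 carbon, 2 nitrogen, 2 oxygen; one six-membered aromatic ring with 2 hetero atoms) in place of a group of 10 heavy atoms (9 carbon, 1 nitrogen; one six-membered aromatic ring of carbon only, one six-membered aromatic ring with 1 hetero atom), on a carbonyl carbon. Within the data shown here, the only measured step that bears on this is the one from compound 1 to compound 2, where a group holding a six-membered aromatic ring with one hetero atom and one oxygen was replaced by a pair of fused rings, one of carbon only, and the number rose by a modest amount. Compound 3 goes the other way in kind: the fused rings leave and a single six-membered aromatic ring with two hetero atoms and two carbonyl groups enters, which in its parts is closer to the group of compound 1 than to that of compound 2. A modest fall back toward the number of compound 1 is therefore expected. Compound 3 is estimated to give about 20%, somewhere between 8% and 32%. For compound 3 the expected step is a number 12 percentage points lower from compound 2 to compound 3 (beyond the scatter), and it remains uncertain. It rests on a single measured step only.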

Compound 3, a percentage reported as activity, at one dose (the size of the read-out at that dose, not a potency): 12%
Estimate against measurement, compound 3: 8 percentage points above; the measured number falls inside the stated range.
By their numbers in this assay, from the lowest: compounds 3 and 1 (each within the scatter of the next); then compound 2.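

The new step, a number 20 percentage points lower from compound 2 to compound 3 (beyond the scatter), comes in this assay from a swap on the carbonyl carbon in which both groups hold 10 heavy atoms, so the heavy-atom count alone does not separate quinolin-8-yl from the group that enters. The other step, a number 7 percentage points lower from compound 1 to compound 3 (within the scatter), shows that the two groups with a single six-membered aromatic ring cannot be told apart here, even though they differ in heavy-atom count, so among these three compounds only the quinolin-8-yl compound stands apart from both of the others. No measurement of any property of these compounds is available to explain the difference, so the reason for it remains unknown.

The compounds shown do not separate the effect of having two fused rings from that of the particular atoms in quinolin-8-yl, and a naphthyl group, with two fused rings of carbon only, or a phenyl group, with one ring of carbon only, would help to pull these apart. Each read-out also comes from one dose, which leaves open how these compounds would compare at other doses.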